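This account rests on a few compounds, and the source may have more. Where it says the series, first, only, none or still open, it means among the compounds named here.

Working notes on the series. Compound 1 `CC1=C(C(=O)OC(C)(C)C)C(c2ccco2)NC(=O)N1C` and compound 2 `CCCOC(=O)C1=C(C)N(C)C(=O)NC1c1ccoc1` have been run in an assay on membranes from CHO cells for displacement of a labelled ligand from adenosine receptor A1 (Homo sapiens), read by scintillation counting, with a stated time of 60 min, tested at 1 uM (a higher number here means more inhibition at the concentration tested (going by the name of the read-out), a lower number less inhibition), where compound 1 gives 44% and compound 2 gives 1%. Within the data shown here, compound 2 thus stands lowest of the two numbers measured, with compound 1 the only neighbour, well beyond the scatter. Compound 1 and compound 2 differ in more than one place, so their pair does not isolate any single change.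

Compound 3 `CC1=C(C(=O)OC(C)(C)C)C(c2ccoc2)NC(=O)N1C` is not yet measured. It departs from compound 2 by tert-butyl in place of propyl on an oxygen next to a carbonyl group. Among the measured compounds shown here, no measured pair in the set carries this change alone, so its size is unknown here; the only guide is that the one compound bearing tert-butyl, compound 1, sits far higher than compound 2 in this assay. A moderate rise is expected for compound 3, with a number 14 percentage points higher from compound 2 to compound 3 (beyond the scatter), though a result within the scatter of compound 2 remains quite possible. The estimate for compound 3 in this assay is 15%, between 0% and 40%.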

Compound 3, a percentage reported as inhibition, at one concentration (the size of the read-out at that concentration, not a potency): 21%
Compound 3: the middle estimate sits 6 percentage points below what was measured; measured number inside the range.
By their numbers in this assay, from the lowest: compound 2; then compound 3; then compound 1.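

In this assay, among these compounds, tert-butyl in place of propyl on an oxygen next to a carbonyl group gives a number 20 percentage points higher from compound 2 to compound 3 (beyond the scatter) and so provides the first reading of this change on its own, with furan-3-yl held fixed. With tert-butyl held fixed, furan-3-yl in place of furan-2-yl on a saturated ring carbon gives a number 23 percentage points lower from compound 1 to compound 3 (beyond the scatter) and shows that the ring attachment also moves the number. Compound 3 therefore separates two places that compound 1 and compound 2 could not, and both changes lie beyond the scatter.

From the compounds shown here alone, it remains open whether isopropyl or a longer chain such as butyl on the same oxygen would move the number further, and whether the tert-butyl step would hold with furan-2-yl on the ring. Nothing available on these compounds explains either step.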